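Vinyl added to the phenyl of compound 2

The source may report more compounds than this note shows. Statements on the series, on what has been measured and on what is new or still open speak of the compounds shown alone.

In a functional assay on HeLa cells (Homo sapiens) for inhibition, read by CCK-8 assay, with a stated time of 48 h (a higher number here means a weaker inhibitor, a lower number a stronger inhibitor), compound 1 `Cn1ccc2cc(-c3cc4nccc(-c5ccc(F)cc5)n4n3)ccc21` gives 5210 nM and compound 2 `COc1cc(-c2ccnc3cc(-c4ccccc4)nn23)cc(OC)c1OC` gives 458 nM as the lower of the two numbers, a gap beyond the scatter. The change vinyl in place of hydrogen on an aromatic carbon puts vinyl in place of hydrogen on an aromatic carbon, para to a large group, and turns phenyl into 4-vinylphenyl. This gives compound 3 `C=Cc1ccc(-c2cc3nccc(-c4cc(OC)c(OC)c(OC)c4)n3n2)cc1` from compound 2. Going by the values given here, no measured pair shows this change, so the expectation is loose. A modest step toward a lower number is expected (a 2.3-fold lower number from compound 2 to compound 3 (0.36 log units; beyond the scatter)) and it would lie just beyond the scatter. The estimated value for compound 3 is 200 nM (range 40 nM to 900 nM).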

Compound 3, half-maximal inhibitory concentration: 882 nM
The estimate for compound 3 lay 4.4-fold (0.64 log units) below the measured number; measured number inside the range.
By their numbers in this assay, from the lowest: compounds 2 and 3 (each within the scatter of the next); then compound 1.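

In this assay, vinyl in place of hydrogen on the phenyl, para to a large group, gives a 1.9-fold higher number from compound 2 to compound 3 (0.28 log units; within the scatter) and so does not separate 4-vinylphenyl from phenyl. This position therefore takes the added vinyl without a shift beyond the scatter. Nothing available explains this result. Still open, on these data alone, is whether an amine, a carboxylic acid or a longer chain at this position would move the number beyond the scatter. Also open, as far as these compounds go, is whether vinyl would behave the same way elsewhere on the shared core.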